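The compounds below may be only part of what the source reports. "The series", "measured", "known", "first", "only" and "open" are said of these compounds alone.

Measured in a functional assay on HCT-116 cells (Homo sapiens) for inhibition, read by sulforhodamine B assay, with a stated time of 48 h, tested at 50 uM; on this read-out lower numbers stand for less inhibition of growth and higher numbers for more inhibition of growth at the one concentration tested:
- compound 1 `COc1cc(/C=C/C(=O)/C=C/c2cccc3ccccc23)ccc1OCc1cn(CCOc2cc(=O)oc3ccccc23)nn1`: 83%
- compound 2 `COc1cccc(/C=C/C(=O)/C=C/c2ccc(OCc3cn(CCCCOc4cc(=O)oc5ccccc45)nn3)c(OC)c2)c1`: 44%

Compound 1, at 83%, holds the higher of the two numbers, and the gap down to compound 2 lies beyond the scatter. Compound 3 `COc1cccc(/C=C/C(=O)/C=C/c2ccc(OCc3cn(CCOc4cc(=O)oc5ccccc45)nn3)c(OC)c2)c1` has not yet been measured. It departs from compound 1 in one place: 3-methoxyphenyl in place of naphthalen-1-yl on a double-bonded chain carbon bound to a double-bonded chain carbon. Among the compounds with values here, no measured step isolates this change, so its size in this assay cannot be read directly. Within the data shown here, the only other reference is compound 2 at 44%, so a moderate loss of growth inhibition is expected, probably beyond the scatter, though the evidence is thin. The expected change is a number 21 percentage points lower from compound 1 to compound 3 (beyond the scatter). For compound 3 the estimated value is 62%, with an expected range of 42% to 82%.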

Compound 3, percent growth inhibition at one concentration: 70%
Compound 3: the middle estimate sits 8 percentage points below what was measured, within the range that was stated.
By their numbers in this assay, from the lowest: compound 2; then compound 3; then compound 1.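

In this assay, 3-methoxyphenyl in place of naphthalen-1-yl on a double-bonded chain carbon bound to a double-bonded chain carbon gives a number 13 percentage points lower from compound 1 to compound 3 (beyond the scatter) as the first step read at this position. The position therefore accepts a single aromatic ring in place of the two of naphthalen-1-yl with a modest loss, and compound 3 at 70% keeps substantial growth inhibition at the one concentration tested. The step removes a ring and adds a methoxy group together, and no measurement at hand accounts for its size.

A plain phenyl at this position would be needed to separate those two parts of the change. From the compounds shown here alone, how a basic group such as a dimethylamino substituent, or a carboxylic acid, on this ring would read remains open, as does any dose-response behaviour.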